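The compounds below may be only part of what the source reports. "The series", "measured", "known", "first", "only" and "open" are said of these compounds alone.

Compound 1 `Cc1ccsc1/C=C(/SCc1ccc(Cl)c(Cl)c1)C(=O)c1ccc(Cl)cc1` and compound 2 `Cc1ccc(S/C(=C/c2sccc2C)C(=O)c2ccc(Cl)cc2)cc1` share one core. In a functional assay on DU-145 cells (Homo sapiens) for inhibition, read by trypan blue exclusion, with a stated time of 96 h (on this read-out higher numbers stand for weaker inhibition of growth and lower numbers for stronger inhibition of growth), compound 1 gives 50000 nM and compound 2 gives 50000 nM. The change between them is 3,4-dichlorobenzyl in place of 4-methylphenyl on a sulfur, and it produced no change at the digits printed from compound 2 to compound 1 (within the scatter). Compound 3 `Cc1ccc(S/C(=C/c2c(O)cc(O)cc2O)C(=O)c2ccc(Cl)cc2)cc1` carries a different core; the difference is 2,4,6-trihydroxyphenyl in place of 3-methylthiophen-2-yl on a double-bonded chain carbon bound to a double-bonded chain carbon. In this assay compound 3 reaches only a limit, > 100000 nM, which is the limit of > 100000 nM in this assay, at which 1 of the 3 values shown sits. That core change gave an at least 2.0-fold higher number from compound 2 to compound 3 (0.30 log units; that floor lies within the scatter). Compound 4 `O=C(/C(=C\c1c(O)cc(O)cc1O)SCc1ccc(Cl)c(Cl)c1)c1ccc(Cl)cc1` is not yet measured; it differs from compound 3 by 3,4-dichlorobenzyl in place of 4-methylphenyl on a sulfur, the same change as that made from compound 2 to compound 1, at a place described in the same words. Because no change at the digits printed from compound 2 to compound 1 (within the scatter), the expected step in this assay is a number no higher from compound 3 to compound 4 (the limit leaves the size open). Compound 4 is therefore estimated at 100000 nM in this assay, with a likely range from 30000 nM to 300000 nM, and most probably again only a limit.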

Compound 4, concentration for 50% growth inhibition: 25000 nM
Compound 4: middle estimate off by 4.0-fold (0.60 log units), on the high side; the measured number lies below the stated range.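

In this assay, 3,4-dichlorobenzyl in place of 4-methylphenyl on a sulfur gave an at least 4.0-fold lower number from compound 3 to compound 4 (0.60 log units; beyond the scatter), so this change did not carry over unaltered from one core to the other: the same change on two cores in this assay, no change at the digits printed (within the scatter) from compound 2 to compound 1 and an at least 4.0-fold lower number (0.60 log units; beyond the scatter) from compound 3 to compound 4, at least 4.0-fold (0.60 log units) apart, beyond the scatter of two such steps. The value of compound 3, > 100000 nM, is a limit, so the size of that step stays open, and two pairs give neither a rule for other cores nor a cause. Read the other way, 2,4,6-trihydroxyphenyl in place of 3-methylthiophen-2-yl gave a 2.0-fold lower number from compound 1 to compound 4 (0.30 log units; within the scatter), and this core change also depends on the group on the sulfur: the same change on two cores in this assay, an at least 2.0-fold higher number (0.30 log units; that floor lies within the scatter) from compound 2 to compound 3 and a 2.0-fold lower number (0.30 log units; within the scatter) from compound 1 to compound 4, at least 4.0-fold (0.60 log units) apart, beyond the scatter of two such steps.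

Still open, going by these compounds, is how an amine or a carboxylic acid in place of 3,4-dichlorobenzyl on the sulfur would read in this assay. Also open, on these data alone, is whether either core would respond in the same way to such a group.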